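The compounds below may be only part of what the source reports. "The series", "measured", "known", "first", "only" and "open" are said of these compounds alone.

The series shares one core, an aryl-triazole methyl ether joined to a bicyclic phenol. Compound 1 `Cc1ccc(-n2cc(COc3ccc4c(c3)CCC4)nn2)c(C)c1` carries two methyl groups on its aryl ring; compound 2 `Cc1ccc(-n2cc(COc3ccc4c(c3)CCC4)nn2)cc1` carries a single one. Going by the values given here, in an ADME assay on HEK293 cells (Homo sapiens) for inhibition, read by MTT assay, with a stated time of 48 h, tested at 25 uM (on this read-out higher numbers stand for more inhibition at the one concentration tested (going by the name of the read-out) and lower numbers for less inhibition), compound 1 gives 19.9%, the only number reported in the set, whereas for compound 2 the entry reads "not determined" (no result reported), with no result recorded. Compound 1 therefore stands alone, with nothing measured to compare against.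

Compound 3 `Cc1cc(C)c(-n2cc(COc3ccc4c(c3)CCC4)nn2)c(C)c1` differs from compound 1 in one place: methyl in place of hydrogen on an aromatic carbon. Among the compounds with values here, no measured pair within the set shows what such a change does in this assay, so the expectation rests on compound 1 alone. The step from compound 1 to compound 3 is expected to be small, a number 2.1 percentage points higher from compound 1 to compound 3 (within the scatter), not clearly beyond the scatter in either direction. Compound 3 is thus estimated at 22%, within a range of 5% to 40%.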

Compound 3, a percentage reported as inhibition, at one concentration (the size of the read-out at that concentration, not a potency): 16.6%
Estimate against measurement, compound 3: 5.4 percentage points above, within the range that was stated.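

In this assay, going by these compounds alone, the pair gives the first measured step of the set, a number 3.3 percentage points lower from compound 1 to compound 3 (within the scatter) for methyl in place of hydrogen on an aromatic carbon. At this place, ortho to a large group and meta to two methyl groups, the added methyl therefore leaves the reading of compound 3 indistinguishable from that of compound 1, although this rests on a single pair at one concentration. Nothing at hand gives a reason for this result.

From the compounds shown here alone, the step between compound 2 and compound 1 cannot be read, as compound 2 has no number, so the effect of the other methyl group on the aryl ring stays unknown. Going by these compounds, whether a group other than methyl at this place, such as an amine, a carboxylic acid or a longer chain, would shift the reading beyond the scatter also remains open.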